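Lengthening a Side Chain on a Shared Core

This account rests on a few compounds, and the source may have more. Where it says the series, first, only, none or still open, it means among the compounds named here.

Three measured compounds and one still to be tested share a single core and differ in the side chains attached to it. Compound 1 `CC1=C([Se]CC(OC(=O)[C@@H](CSSC(C)(C)C)NC(=O)OC(C)(C)C)C(=O)NC(C)(C)C)C(=O)c2ccccc2C1=O` in a functional assay on A498 cells (Homo sapiens) for cytotoxicity, read by MTT assay, with a stated time of 24 h (on this read-out higher numbers stand for weaker inhibition and lower numbers for stronger inhibition), gives 5000 nM. Compound 2 `CC1=C(SCCC(=O)OC(C[Se]c2ccccc2)C(=O)NCCCCCC(=O)OCc2ccccc2)C(=O)c2ccccc2C1=O` in this assay reaches only the limit of > 100000 nM, so no number is known for it. Compound 3 `CC1=C(SCCC(=O)OC(C[Se]c2ccccc2)C(=O)NC(C)(C)C)C(=O)c2ccccc2C1=O` likewise reaches only the limit of > 100000 nM. Compound 3 therefore stands at the weak end of what has been seen, sitting at the limit of > 100000 nM in this assay, at which 2 of the 3 values shown sit. Compound 4 `CC1=C(SCCC(=O)OC(CC[Se]c2ccccc2)C(=O)NC(C)(C)C)C(=O)c2ccccc2C1=O` differs from compound 3 by a group of 8 heavy atoms (7 carbon, 1 selenium; one six-membered aromatic ring of carbon only) in place of a group of 7 heavy atoms (6 carbon, 1 selenium; one six-membered aromatic ring of carbon only), on a saturated chain carbon, two bonds along the chain from a carbonyl carbon and an oxygen next to a carbonyl group: a group of 8 heavy atoms (7 carbon, 1 selenium; one six-membered aromatic ring of carbon only) in place of a group of 7 heavy atoms (6 carbon, 1 selenium; one six-membered aromatic ring of carbon only), on a saturated chain carbon, two bonds along the chain from a carbonyl carbon and an oxygen next to a carbonyl group. Among the measured compounds shown here, no step between measured compounds is available to guide this change, so the step of a number no higher from compound 3 to compound 4 (the limit leaves the size open) is expected to be none beyond the scatter. Compound 4 is accordingly expected to give about 100000 nM in this assay, most likely again as a limit, within a range from 30000 nM to 300000 nM.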

Compound 4, half-maximal inhibitory concentration: > 100000 nM
Compound 4: no number, only a limit; the forecaster's own chance of this, stated with the estimate: 75%; the middle value sits exactly at the limit.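

Compound 3 and compound 4 each give only a limit of the assay rather than a number, so no step can be read between them. The compounds shown leave open whether swapping the group of 7 heavy atoms for the group of 8 heavy atoms changes activity at all.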